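Trimethoxyphenyl amide series: warhead swap on the carbonyl

The compounds below may be only part of what the source reports. "The series", "measured", "known", "first", "only" and "open" are said of these compounds alone.

Measured compounds:
compound 1 `C#CC(=O)N(Cc1ccc(OC)c(O)c1)c1cc(OC)c(OC)c(OC)c1` — 170 nM
compound 2 `C/C=C/C(=O)N(Cc1ccc(OC)c(Br)c1)c1cc(OC)c(OC)c(OC)c1` — 6430 nM

In a functional assay on MGC-803 cells (Homo sapiens) for inhibition, read by MTT assay, with a stated time of 48 h (a higher number here means a weaker inhibitor, a lower number a stronger inhibitor), compound 1 gives 170 nM, the lowest of the two numbers recorded. Compound 2 gives 6430 nM in this assay, a markedly higher number, beyond the scatter; the two structures differ in more than one place, so only their two values are compared here.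

Compound 3 `COc1ccc(CN(C(=O)C[Se]C#N)c2cc(OC)c(OC)c(OC)c2)cc1O` has not been measured. Against compound 1 the change is a group of 4 heavy atoms (2 carbon, 1 nitrogen, 1 selenium; no ring) in place of a group of 2 heavy atoms (2 carbon; no ring), on a carbonyl carbon. The shared core and the methoxy-hydroxy benzyl portion are unchanged.

With no measured step of this kind in the series, the expectation rests only on compound 1 at 170 nM. A moderate weakening is expected, the step from compound 1 to compound 3 being estimated at a 2.9-fold higher number from compound 1 to compound 3 (0.47 log units; beyond the scatter), though a result within the scatter of compound 1 is not ruled out. Compound 3 is estimated at 500 nM, with a range of 120 nM to 2500 nM.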

Compound 3, half-maximal inhibitory concentration: 270 nM
The estimate for compound 3 lay 1.9-fold (0.27 log units) above the measured number, and the stated range covers the measured number.
By their numbers in this assay, from the lowest: compounds 1 and 3 (each within the scatter of the next); then compound 2.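

On the carbonyl carbon, with the methoxy-hydroxy benzyl portion and the shared core held constant, exchanging the ethynyl group for the group of 4 heavy atoms containing selenium gives, in this assay, a 1.6-fold higher number from compound 1 to compound 3 (0.20 log units; within the scatter). This is the only one-place step shown, and it indicates that the ethynyl group is not required at this position for a value in this range, at least for this one replacement. No measured evidence here accounts for this result.

Going by these compounds, it remains open whether the selenium atom matters, and a sulfur atom in its place or a plain methyl group or an amine on the carbonyl carbon would test the position further. The high value of compound 2 also cannot be assigned to its carbonyl group or to its bromine, as these two changes are not separated.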